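Adding Bromo to the Phenyl Ring of Compound 3

The source may report more compounds than this note shows. Statements on the series, on what has been measured and on what is new or still open speak of the compounds shown alone.

- compound 1 `COc1ccc(/C=C2\CCC/C(=C\c3cccc(OC)c3OC)C2=O)cc1`: 401000 nM
- compound 2 `COc1ccc(/C=C2\CCC/C(=C\c3ccc(Br)cc3)C2=O)cc1`: 250000 nM
- compound 3 `COc1cccc(/C=C2\CCC/C(=C\c3ccccc3)C2=O)c1OC`: 33500 nM

In an ADME assay on Vero cells (Chlorocebus sabaeus) for inhibition (on this read-out lower numbers stand for higher toxicity in this test and higher numbers for lower toxicity in this test), compound 3 gives the lowest number of the three, at 33500 nM. The next structure is compound 4 `COc1cccc(/C=C2\CCC/C(=C\c3ccc(Br)cc3)C2=O)c1OC`, which has not yet been measured. It turns the phenyl of compound 3 into 4-bromophenyl, with bromo in place of hydrogen on an aromatic carbon.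

Within the data shown here, one measured step bears on this change. It is a 12-fold lower number from compound 1 to compound 3 (1.08 log units; beyond the scatter), a large step, with hydrogen in place of methoxy on an aromatic carbon. Compound 4 goes the opposite way, since a hydrogen gives way to a heavier group. Compound 2 also carries 4-bromophenyl and gives 250000 nM. Among the measured compounds shown here, no measured step exchanges hydrogen for bromo directly, so the size remains uncertain. A clear rise in this assay is expected, probably somewhat smaller than the measured step. The expected step is a 4.5-fold higher number from compound 3 to compound 4 (0.65 log units; beyond the scatter). For compound 4 the estimated value is 150000 nM, with an expected range from 50000 nM to 400000 nM.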

Compound 4, half-maximal cytotoxic concentration: 31500 nM
Compound 4: middle estimate off by 4.8-fold (0.68 log units), on the high side; the measured number lies below the stated range.
By their numbers in this assay, from the lowest: compounds 4 and 3 (each within the scatter of the next); then compounds 2 and 1 (each within the scatter of the next).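

In this assay, putting bromo on this ring carbon leaves the number where it was, a 1.1-fold lower number from compound 3 to compound 4 (0.03 log units; within the scatter), so at this position bromo and hydrogen cannot be told apart. Methoxy now stands apart from both: exchanging it for bromo gives a 13-fold lower number from compound 1 to compound 4 (1.10 log units; beyond the scatter), about the same large step as exchanging it for hydrogen, a 12-fold lower number from compound 1 to compound 3 (1.08 log units; beyond the scatter). The compounds shown offer no measurement that explains why methoxy differs from the other two groups.

Three groups at one position cannot show whether compound 1's high number belongs to methoxy alone or would also appear with another group attached through oxygen, such as ethoxy or hydroxy. From the compounds shown here alone, it also remains open where an amine or a carboxylic acid at this position would fall relative to compound 1 and compound 3.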